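Replacing ethyl with hydrogen on compound 3

A few compounds are considered here, and "the series" means these few. Any claim that something is new, unique, unknown or untested is made for them only; others in the source may bear on it.

In a physicochemical assay for solubility, read by HPLC, at pH 6.5 (a lower number here means a less soluble compound, a higher number a more soluble compound), compound 1 `O=C1CC2(CCN(CCC3CCCCC3)CC2)Oc2c1ccc1ccccc21` gives 10000 nM, and compound 2 `CCN1CCC2(CC1)CC(O)c1ccc3ccccc3c1O2` gives 20000 nM. Compound 3 `CCN1CCC2(CC1)CC(=O)c1ccc3ccccc3c1O2` gives only a limit, >= 80000 nM. It stands at the limit of >= 80000 nM in this assay, at which 1 of the 3 values shown sits. Compound 4 `O=C1CC2(CCNCC2)Oc2c1ccc1ccccc21` differs from compound 3 by one change, hydrogen in place of ethyl on an amine nitrogen in a ring. For the measured compounds named here, the one measured step that bears on this, an at least 8.0-fold higher number from compound 1 to compound 3 (0.90 log units; beyond the scatter), put hydrogen in place of cyclohexyl and lies beyond the scatter. Yet cyclohexyl and ethyl are different groups, and compound 3 offers a limit rather than a number to start from. The expected result is a step that the limit leaves unreadable from compound 3 to compound 4, a step no larger than the scatter. Compound 4 is estimated at 90000 nM, with an expected range from 40000 nM to 160000 nM.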

Compound 4, solubility: >= 80000 nM
Compound 4: only a limit was reported (the forecaster's own chance of this, stated with the estimate: 60%); the middle value lies beyond the limit too.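

In this assay compound 4, with hydrogen in place of ethyl on the amine nitrogen in a ring, gives only a limit, >= 80000 nM, so the step from compound 3 cannot be read. On that same nitrogen, hydrogen in place of 2-cyclohexylethyl gives an at least 8.0-fold higher number from compound 1 to compound 4 (0.90 log units; beyond the scatter), a comparison made at this position alone. Compound 3 and compound 4 both end at one limit, so ethyl and hydrogen cannot be told apart here: the limit of >= 80000 nM in this assay, at which 2 of the 4 values shown sit.

Open, as far as these compounds go, is whether a butyl chain or an acetyl group on that nitrogen would give a readable number. Where along the way to 2-cyclohexylethyl such a number would first appear also stays open.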